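A few compounds are considered here, and "the series" means these few. Any claim that something is new, unique, unknown or untested is made for them only; others in the source may bear on it.

Compound 1 `CC(C)c1onc(-c2c(Cl)cccc2Cl)c1COc1ccc(NCc2ccc(C(=O)O)cc2)c(C(F)(F)F)n1`: 45%
Compound 2 `CC(C)c1onc(-c2c(Cl)cccc2Cl)c1COc1ccc(N(C)Cc2ccc(CCC(=O)O)cc2)c(C(F)(F)F)n1`: 66%

In a functional assay on HEK293 cells for agonist activity at Bile acid receptor (Homo sapiens), read by a luciferase reporter (on this read-out lower numbers stand for smaller maximal responses and higher numbers for larger maximal responses), compound 2 gives 66%, the highest of the two numbers. Compound 1 gives 45%, a number that lies beyond the usual scatter below compound 2. Among the measured compounds shown here, compound 1 and compound 2 differ in more than one place, so no single step between measured compounds can be read from this pair; only the two values themselves are available.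

Compound 3 `CC(C)c1onc(-c2c(Cl)cccc2Cl)c1COc1ccc(N(C)Cc2ccc(OCCO)cc2)c(C(F)(F)F)n1` differs from compound 2 in one place: 2-hydroxyethoxy in place of 2-carboxyethyl on an aromatic carbon. The 2-carboxyethyl group leaves and a 2-hydroxyethoxy group enters, on the aromatic carbon para to a large group. For the measured compounds named here, no measured pair shows what such a change does here, and the two measured compounds offer no guide to it. The step from compound 2 to compound 3 is expected to be downward, of a size beyond the scatter, roughly a number 26 percentage points lower from compound 2 to compound 3 (beyond the scatter). For compound 3 the expected value in this assay is 40%, with a likely range from 15% to 65%.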

Compound 3, largest response reached (reported as efficacy), in percent of the reference or control that the assay uses: 59%
Estimate against measurement, compound 3: 19 percentage points below; the measured number falls inside the stated range.
By their numbers in this assay, from the lowest: compound 1; then compounds 3 and 2 (each within the scatter of the next).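

In this assay, putting 2-hydroxyethoxy in place of 2-carboxyethyl on the aromatic carbon para to a large group gives a number 7 percentage points lower from compound 2 to compound 3 (within the scatter), so this read-out cannot tell the two compounds apart. Among the compounds shown here, this is the first single change seen at this position, and it shows that the carboxylic acid of the 2-carboxyethyl group is not needed here for a maximal response of this size, since a chain ending in a hydroxyl group serves as well in this pair. Nothing measured here explains why the two groups can be exchanged in this way.

This single pair cannot show whether the position accepts almost any group or only certain ones, such as those ending in a carboxylic acid or a hydroxyl group. From the compounds shown here alone, how a 2-aminoethoxy group, a longer chain such as 3-hydroxypropoxy, or a bare hydrogen on the same carbon would behave remains open, as does whether the same exchange would give a similar result with the rest of the molecule altered.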